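Hydrogen to Methyl on the Core of Compound 3

The compounds below may be only part of what the source reports. "The series", "measured", "known", "first", "only" and "open" are said of these compounds alone.

In a functional assay on K562 cells (Homo sapiens) for inhibition, read by fluorescence, with a stated time of 72 h (on this read-out higher numbers stand for weaker inhibition of growth and lower numbers for stronger inhibition of growth), compound 1 `Cc1nc(CCO)cc2nn(-c3ccccc3)cc12` gives > 100000 nM, which is a limit of the assay and not a number (the limit of > 100000 nM in this assay, at which 1 of the 3 values shown sits). Compound 2 `CCCCc1cc2nn(-c3ccccc3)cc2c(C(C)C)n1` gives 12900 nM in this assay. Compound 3 `CCCCc1cc2nn(-c3ccccc3)cc2cn1` gives 6700 nM in this assay, the lowest of the two numbers, with compound 2 nearest; the step of a 1.9-fold lower number from compound 2 to compound 3 (0.28 log units; within the scatter) lies within the scatter. Compound 4 `CCCCc1cc2nn(-c3ccccc3)cc2c(C)n1` differs from compound 3 by methyl in place of hydrogen on an aromatic carbon. Going by the values given here, only one measured step bears on this position, a 1.9-fold lower number from compound 2 to compound 3 (0.28 log units; within the scatter), and it stayed within the scatter, so no step beyond the scatter is expected here, the expected step being a 1.2-fold higher number from compound 3 to compound 4 (0.08 log units; within the scatter). Compound 4 is therefore estimated at 8000 nM, with a range from 3000 nM to 25000 nM.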

Compound 4, concentration for 50% growth inhibition: 8500 nM
For compound 4 the middle estimate is 1.1-fold (0.03 log units) below the measured one; the measured number falls inside the stated range.
By their numbers in this assay, from the lowest: compounds 3, 4 and 2 (each within the scatter of the next). At a limit, above all of these: compound 1.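

With methyl in place, this position, on an aromatic carbon next to the ring nitrogen, has now carried hydrogen, methyl and isopropyl in this assay without any step leaving the scatter (a 1.3-fold higher number from compound 3 to compound 4 (0.10 log units; within the scatter); a 1.5-fold lower number from compound 2 to compound 4 (0.18 log units; within the scatter)). Compound 4 also gives a step beyond the scatter on the chain, with ethyl in place of hydroxy (an at least 11-fold lower number from compound 1 to compound 4 (1.07 log units; beyond the scatter)). That step starts from compound 1, whose value is a limit and not a number: (the limit of > 100000 nM in this assay, at which 1 of the 4 values shown sits).

The compounds shown leave open whether an amine or a carboxylic acid at this position would move the number beyond the scatter.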